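The source may report more compounds than this note shows. Statements on the series, on what has been measured and on what is new or still open speak of the compounds shown alone.

Three hydroxamic acids built on a shared core are in view here. Compound 1 `O=C(CCC1=CCCN(Cc2ccc(F)cc2)C1=O)NO` was run in a functional assay on ACHN cells (Homo sapiens) for inhibition, read by sulforhodamine B assay (on this read-out higher numbers stand for weaker inhibition of growth and lower numbers for stronger inhibition of growth), where compound 1 shows "not determined" (no result reported), so it contributes no number. Compound 2 `Cc1ccc(CN2CCC=C(CCC(=O)NO)C2=O)cc1` gives 5000 nM in this assay, and since this is the only number shown, compound 2 stands simply as the one point of reference rather than as the stronger or weaker of a pair. Compound 3 `COc1ccc(CN2CCC=C(CCC(=O)NO)C2=O)cc1` has not yet been measured. It differs from compound 2 in a single place (methoxy in place of methyl on an aromatic carbon). Among the measured compounds shown here, with no step between two measured compounds available, there is nothing in these data to show how such a swap shifts the read-out, so the fairest expectation is a small step, in no clear direction, staying within the usual scatter of repeated measurements in this assay. On that basis compound 3 is expected to give about 4500 nM, within a range from 1500 nM to 13000 nM. The step that this estimate means, a 1.1-fold lower number from compound 2 to compound 3 (0.05 log units; within the scatter), is expected to be modest.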

Compound 3, concentration for 50% growth inhibition: 1670 nM
The estimate for compound 3 lay 2.7-fold (0.43 log units) above the measured number; measured number inside the range.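

In this assay, methoxy in place of methyl on an aromatic carbon, para to a large group, gives a 3.0-fold lower number from compound 2 to compound 3 (0.48 log units; beyond the scatter). Among the compounds shown here, this is the first sign that this position on the ring is not indifferent to what sits there, since the step is larger than the scatter expected between repeated measurements and points towards stronger inhibition of growth. The swap is a small one on paper, adding an oxygen that counts as a hydrogen-bond acceptor while bringing no ring and no net charge, but nothing available here explains why it moves the read-out.

For the compounds shown here, compound 1, which carries fluorine on the same ring, shows "not determined" (no result reported) and so offers no further comparison, leaving a single step as the only guide to this position. Still open, as far as these compounds go, is whether an ethoxy group, a hydroxyl or an amine at this same place would carry the number further down or bring it back up, and whether the oxygen or the extra atom of the methoxy group matters more.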